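Extending the Amino Side Chain and Oral Exposure

The source may hold more compounds than are shown below. What is called first, only, known or untested is meant among the compounds shown, and "the series" means these compounds.

Compound 1 `CNc1nc(C)c(-c2nc3ccccc3s2)c(N[C@@H]2C[C@H](CO)[C@@H](O)[C@H]2O)n1` is the simplest member of this small set. In an ADME assay on the whole organism (plasma) for pharmacokinetics, with Rattus norvegicus as the target, with a stated time of 6 h, at a dose of 10 mg/kg by the oral route (on this read-out lower numbers stand for lower exposure and higher numbers for higher exposure at the dose given), compound 1 gives 1080 ng.h/mL. Compound 2 `CCNc1nc(C)c(-c2nc3ccccc3s2)c(N[C@@H]2C[C@H](CO)[C@@H](O)[C@H]2O)n1` differs by methyl in place of hydrogen on a saturated chain carbon bound to a nitrogen on an aromatic ring, and compound 2 gives 2580 ng.h/mL; the step is a 2.4-fold higher number from compound 1 to compound 2 (0.38 log units; beyond the scatter). Compound 3 `COCCNc1nc(C)c(-c2nc3ccccc3s2)c(N[C@@H]2C[C@H](CO)[C@@H](O)[C@H]2O)n1` differs from compound 1 by methoxymethyl in place of hydrogen on a saturated chain carbon bound to a nitrogen on an aromatic ring, and compound 3 gives 2630 ng.h/mL; that step is a 2.4-fold higher number from compound 1 to compound 3 (0.39 log units; beyond the scatter), while a 1.0-fold higher number from compound 2 to compound 3 (0.01 log units; within the scatter).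

Compound 4 `CCOCCNc1nc(C)c(-c2nc3ccccc3s2)c(N[C@@H]2C[C@H](CO)[C@@H](O)[C@H]2O)n1` differs from compound 3 by methyl in place of hydrogen on a saturated chain carbon bound to an oxygen on a saturated carbon. This is the same kind of change as from compound 1 to compound 2, which gave a 2.4-fold higher number from compound 1 to compound 2 (0.38 log units; beyond the scatter), but the place differs: there the added methyl sat on a saturated chain carbon bound to a nitrogen on an aromatic ring, here it sits on a saturated chain carbon bound to an oxygen on a saturated carbon. The two cores themselves differ by methoxymethyl in place of hydrogen on a saturated chain carbon bound to a nitrogen on an aromatic ring. Because a 1.0-fold higher number from compound 2 to compound 3 (0.01 log units; within the scatter) shows that lengthening the chain beyond compound 2 brought no change beyond the scatter, a smaller step than the earlier one is expected from compound 3 to compound 4, about a 1.1-fold higher number from compound 3 to compound 4 (0.06 log units; within the scatter). Compound 4 is therefore estimated at 3000 ng.h/mL, expected to lie between 1500 ng.h/mL and 6000 ng.h/mL.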

Compound 4, area under the concentration-time curve: 1100 ng.h/mL
Beside the measured number, compound 4's estimate is 2.7-fold (0.44 log units) above it, outside the stated range (below it).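

In this assay the added methyl does not carry over from one core to the other: the same change on two cores in this assay, a 2.4-fold higher number (0.38 log units; beyond the scatter) from compound 1 to compound 2 and a 2.4-fold lower number (0.38 log units; beyond the scatter) from compound 3 to compound 4, 5.7-fold (0.76 log units) apart, beyond the scatter of two such steps.

The new step is a 2.4-fold lower number from compound 3 to compound 4 (0.38 log units; beyond the scatter) while ethoxy in place of hydrogen gives a 2.3-fold lower number from compound 2 to compound 4 (0.37 log units; beyond the scatter) and ethoxymethyl in place of hydrogen gives a 1.0-fold higher number from compound 1 to compound 4 (0.01 log units; within the scatter) and so a gain seen on one core cannot be assumed on another in this series. With a single pair on each core, this does not show whether the core or the place of the methyl sets the direction of the step, as the two differ together here.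

The compounds shown leave open how a longer chain such as propoxy, or an amine on this side chain, would behave.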